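Furan-2-yl for phenyl on a topoisomerase inhibitor series

The compounds below may be only part of what the source reports. "The series", "measured", "known", "first", "only" and "open" are said of these compounds alone.

Measured compounds:
compound 1 `Oc1ccc(-c2cc(-c3ccccc3)nc(-c3ccccc3Cl)c2)cc1`, 13.6%
compound 2 `Oc1ccc(-c2cc(-c3ccco3)nc(-c3ccccc3Cl)c2)cc1`, 3.9%
compound 3 `Oc1cccc(-c2cc(-c3ccccc3)nc(-c3ccc(Cl)cc3)c2)c1`, 7.1%

In an assay on isolated protein for inhibition of DNA topoisomerase 1 (Homo sapiens), with a stated time of 30 min, tested at 100 uM (a higher number here means a stronger effect of the compound at the concentration tested, a lower number a weaker effect), compound 1 gives 13.6%. Compound 2 differs from it by furan-2-yl in place of phenyl on an aromatic carbon, and this change made a step of a number 9.7 percentage points lower from compound 1 to compound 2 (within the scatter). Compound 3 has the same atoms as compound 1, joined differently; the difference between the two cores is not broken down here. In this assay compound 3 gives 7.1%, and its value and those of compound 1 and compound 2 lie within the usual scatter of one another, so no order among the three is claimed.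

Compound 4 `Oc1cccc(-c2cc(-c3ccc(Cl)cc3)nc(-c3ccco3)c2)c1` is not yet measured. It differs from compound 3 by furan-2-yl in place of phenyl on an aromatic carbon. This is the same kind of change as that from compound 1 to compound 2, but the surroundings differ: there the place was meta to a 2-chlorophenyl group and meta to a 4-hydroxyphenyl group, here it is meta to a 3-hydroxyphenyl group and meta to a 4-chlorophenyl group. Because the earlier step was a number 9.7 percentage points lower from compound 1 to compound 2 (within the scatter), a step of similar size is expected here, a number 5.1 percentage points lower from compound 3 to compound 4 (within the scatter), resting on that single precedent alone. Compound 4 is therefore estimated to give 2% in this assay, expected to fall between -6% and 14%.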

Compound 4, a percentage reported as inhibition, at one concentration (the size of the read-out at that concentration, not a potency): 27.1%
Compound 4: middle estimate off by 25.1 percentage points, on the low side, and the stated range ends below it.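

In this assay, putting furan-2-yl in place of phenyl gave a number 20 percentage points higher from compound 3 to compound 4 (beyond the scatter). The change therefore does not carry from one core to the other as a step of fixed size, and its effect depends on the core that bears it: the same change on two cores in this assay, a number 9.7 percentage points lower (within the scatter) from compound 1 to compound 2 and a number 20 percentage points higher (beyond the scatter) from compound 3 to compound 4, 29.7 percentage points apart, beyond the scatter of two such steps

What this does not show is which difference between the cores matters, since the core of compound 1 carries 2-chlorophenyl and 4-hydroxyphenyl groups while the core of compound 3 carries 4-chlorophenyl and 3-hydroxyphenyl groups, and these two pairs cannot separate the contribution of either group.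

The compounds shown leave open whether the hydroxyphenyl group or the chlorophenyl group governs the sign of the step, which would take a core differing from one of these in only one of the two groups. They also leave open how the series would respond to an amine or a carboxylic acid in place of the hydroxyl group, and whether a thiophene ring would behave like furan-2-yl.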